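The source may report more compounds than this note shows. Statements on the series, on what has been measured and on what is new or still open speak of the compounds shown alone.

Series notes. Compound 1 `Nc1ccccc1NC(=O)c1ccc(CNC2=NC(=O)C(c3ccccc3)N2)cc1` carries the shared core with an unsubstituted ring nitrogen; in an assay for inhibition of histone deacetylase 8 (Homo sapiens), read by fluorescence, with stated times of 15 min and 60 min (a lower number here means a stronger inhibitor, a higher number a weaker inhibitor), compound 1 gives 8000 nM. Compound 2 `CC(C)(C)OC(=O)N1C(NCc2ccc(C(=O)Nc3ccccc3N)cc2)=NC(=O)C1Cc1c[nH]c2ccccc12` bears a tert-butoxycarbonyl on that nitrogen, and in this assay compound 2 gives 27200 nM, the higher of the two numbers, a gap beyond the usual scatter. Compound 3 `Nc1cc(C(=O)OCc2ccccc2)ccc1NC(=O)c1ccc(CNc2nccc(-c3cccnc3)n2)cc1` reaches only a limit, > 20000 nM in this assay, as recorded in the limit of > 20000 nM in this assay, at which 1 of the 3 values shown sits.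

Compound 4 `CC(=O)N1C(NCc2ccc(C(=O)Nc3ccccc3N)cc2)=NC(=O)C1Cc1c[nH]c2ccccc12` follows from compound 2 by methyl in place of tert-butoxy on a carbonyl carbon. Going by the values given here, no measured pair in the set shows this change, so the step from compound 2 to compound 4 is estimated as a modest drop in the number, a 1.8-fold lower number from compound 2 to compound 4 (0.26 log units; within the scatter), a move expected to stay near the scatter. For compound 4 the expected value in this assay is 15000 nM, within 5000 nM to 45000 nM.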

Compound 4, half-maximal inhibitory concentration: 24300 nM
Beside the measured number, compound 4's estimate is 1.6-fold (0.21 log units) below it; the measured number falls inside the stated range.
By their numbers in this assay, from the lowest: compound 1; then compounds 4 and 2 (each within the scatter of the next).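

Methyl in place of tert-butoxy on this carbonyl carbon is the first step in the series that can be read, and in this assay it gives a 1.1-fold lower number from compound 2 to compound 4 (0.05 log units; within the scatter) on the shared core. Tert-butoxycarbonyl and acetyl on the amide-type nitrogen in a ring therefore cannot be told apart here. No measurement shown accounts for this result.

Open, on these data alone, is whether an amine or a longer chain on this carbonyl carbon would move the number beyond the scatter. Also open, as far as these compounds go, is how the core of compound 2 reads with an unsubstituted ring nitrogen.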